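Trimming One Methoxy Group from Compound 3

A few compounds are considered here, and "the series" means these few. Any claim that something is new, unique, unknown or untested is made for them only; others in the source may bear on it.

Three compounds share one core and differ only in the ring on the carbonyl carbon. In a functional assay on COLO 205 cells (Homo sapiens) for cytotoxicity, read by sulforhodamine B assay, with a stated time of 48 h, tested at 100 uM (a lower number here means a stronger effect, a higher number a weaker effect of the compound at the concentration tested), compound 1 `COc1cc(-c2cc(/C=C/C(=O)c3ccc(N)cc3)[nH]n2)cc(OC)c1OC` gives -78%, compound 2 `COc1cc(-c2cc(/C=C/C(=O)c3ccc(Cl)c(Cl)c3)[nH]n2)cc(OC)c1OC` gives -42%, and compound 3 `COc1ccc(C(=O)/C=C/c2cc(-c3cc(OC)c(OC)c(OC)c3)n[nH]2)cc1OC` gives -75%. Compound 3 stands close to compound 1, because a number 3 percentage points higher from compound 1 to compound 3 (within the scatter), while it is well apart from compound 2, because a number 33 percentage points lower from compound 2 to compound 3 (beyond the scatter). Compound 4 `COc1ccc(C(=O)/C=C/c2cc(-c3cc(OC)c(OC)c(OC)c3)n[nH]2)cc1` is compound 3 with one change: hydrogen in place of methoxy on an aromatic carbon. Going by the values given here, no measured step removes a single methoxy group; the steps that swap the whole ring show that 4-aminophenyl and 3,4-dimethoxyphenyl sit together, with 3,4-dichlorophenyl clearly weaker. A small step, a number 5 percentage points higher from compound 3 to compound 4 (within the scatter), is therefore expected, within the scatter. Compound 4 is estimated at -70%, between -88% and -40%.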

Compound 4, a percentage reported as activity, at one concentration (the size of the read-out at that concentration, not a potency): -81%
Compound 4: the middle estimate sits 11 percentage points above what was measured; the range from low to high includes it.
By their numbers in this assay, from the lowest: compounds 4, 1 and 3 (each within the scatter of the next); then compound 2.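

In this assay, the step that removes one methoxy group directly (a number 6 percentage points lower from compound 3 to compound 4 (within the scatter)) shows that 3,4-dimethoxyphenyl and 4-methoxyphenyl cannot be told apart at this concentration. Going by these compounds alone, the single methoxy group is enough to keep the clear separation from the dichlorinated ring (a number 39 percentage points lower from compound 2 to compound 4 (beyond the scatter)), and the 4-aminophenyl ring still cannot be told apart from it (a number 3 percentage points lower from compound 1 to compound 4 (within the scatter)). No available measurement explains why this methoxy group can be lost. Still open, from the compounds shown here alone, is whether an ethoxy group or a carboxylic acid at this place would give the same reading, and whether plain phenyl, with no methoxy group at all, would hold up too.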